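The source may hold more compounds than are shown below. What is called first, only, known or untested is meant among the compounds shown, and "the series" means these compounds.

Measured compounds in a functional assay on A549 cells (Homo sapiens) for antiproliferative activity, read by MTT assay, with a stated time of 48 h; on this read-out lower numbers stand for stronger inhibition and higher numbers for weaker inhibition:
compound 1 `O=C(Cc1ccc(F)cc1)NS(=O)(=O)c1ccc(F)cc1` — 5.64 ug/mL
compound 2 `O=C(Cc1ccc(F)cc1)NS(=O)(=O)c1ccccc1` — 10.1 ug/mL

For the measured compounds named here, compound 2 stands at the higher of the two numbers, but the only step between the two, a 1.8-fold higher number from compound 1 to compound 2 (0.25 log units; within the scatter), lies within the scatter, so the pair cannot be ordered on this assay. Compound 3 `Cc1ccc(S(=O)(=O)NC(=O)Cc2ccc(F)cc2)cc1` has not yet been measured. It differs from compound 2 by methyl in place of hydrogen on an aromatic carbon; the site is an aromatic carbon of a six-membered aromatic ring of carbon only, para to a large group. Going by the values given here, no measured step involves a methyl group. Among the compounds with values here, the one step available, a 1.8-fold higher number from compound 1 to compound 2 (0.25 log units; within the scatter), also concerns a single small substituent on an aromatic carbon, and it stayed within the scatter. Going by these compounds, on that basis, the change to compound 3 is not expected to move the number beyond the scatter in either direction, and the direction itself stays open. For compound 3 the expected step is a 1.2-fold lower number from compound 2 to compound 3 (0.07 log units; within the scatter). Compound 3 is estimated at 8.5 ug/mL, with a range from 4 ug/mL to 18 ug/mL.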

Compound 3, half-maximal inhibitory concentration: 12 ug/mL
Estimate against measurement, compound 3: 1.4-fold (0.15 log units) below; the measured number falls inside the stated range.
By their numbers in this assay, from the lowest: compounds 1, 2 and 3 (each within the scatter of the next, the first and the last beyond it).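

In this assay, methyl on the aromatic carbon para to a large group gives a 1.2-fold higher number from compound 2 to compound 3 (0.07 log units; within the scatter), so this position accepts a group with one carbon in place of hydrogen without a readable change, and compound 2 and compound 3 cannot be ordered. For the compounds shown here, the comparison of methyl with fluoro at the same place gives a 2.1-fold higher number from compound 1 to compound 3 (0.33 log units; beyond the scatter), the first step beyond the scatter, although it is modest and the steps from hydrogen to either group are not. Nothing shown bears on the reason for this separation between the fluoro and methyl compounds.

Going by these compounds, it remains open whether an amine, a carboxylic acid or a longer chain such as propyl at this aromatic carbon would move the number clearly away from that of compound 2. With only hydrogen, fluoro and methyl represented here, the series also leaves open whether a methoxy or trifluoromethyl group would fall with these three compounds or outside their narrow spread.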